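Removing the Fused-Ring Methyl from Compound 3

This account rests on a few compounds, and the source may have more. Where it says the series, first, only, none or still open, it means among the compounds named here.

In an assay on isolated protein for inhibition of alpha-ketoglutarate-dependent dioxygenase alkB homolog 3 (Homo sapiens), read by polymerase chain reaction, with a stated time of 1 h (a lower number here means a stronger inhibitor, a higher number a weaker inhibitor), compound 3 `Cc1ccc2[nH]c(-n3[nH]c(C)c(Cc4ccccc4Cl)c3=O)nc2c1` gives 910 nM, the second highest of the three numbers measured. Compound 1 `Cc1ccc2[nH]c(-n3[nH]c(C)c(Cc4ccccc4)c3=O)nc2c1` gives 670 nM, and the step of a 1.4-fold higher number from compound 1 to compound 3 (0.13 log units; within the scatter) stays within the scatter. Compound 2 `Cc1ccc2[nH]c(-n3[nH]c(C)c(C)c3=O)nc2c1` gives 2600 nM, and the step of a 2.9-fold lower number from compound 2 to compound 3 (0.46 log units; beyond the scatter) goes beyond it. Compound 4 `Cc1[nH]n(-c2nc3ccccc3[nH]2)c(=O)c1Cc1ccccc1Cl` differs from compound 3 by hydrogen in place of methyl on an aromatic carbon. Among the measured compounds shown here, no measured step bears on this change: the steps of a 3.9-fold higher number from compound 1 to compound 2 (0.59 log units; beyond the scatter) and a 1.4-fold higher number from compound 1 to compound 3 (0.13 log units; within the scatter) concern only the group on the saturated chain carbon. With nothing to point either way, a change within the scatter is expected, an estimated 1.2-fold higher number from compound 3 to compound 4 (0.08 log units; within the scatter). Compound 4 is therefore expected to give about 1100 nM, with an estimated range from 450 nM to 2700 nM.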

Compound 4, half-maximal inhibitory concentration: > 10000 nM
Compound 4: a limit, no number (the forecaster's own chance of this, stated with the estimate: 3%); middle value at least 9.0-fold (0.95 log units) from the limit.
By their numbers in this assay, from the lowest: compounds 1 and 3 (each within the scatter of the next); then compound 2. At a limit, above all of these: compound 4.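

In this assay, replacing the methyl on this aromatic carbon with hydrogen gives an at least 10-fold higher number from compound 3 to compound 4 (1.04 log units; beyond the scatter). Among the compounds shown here, this single-carbon change at the fused ring has a larger effect than any of the earlier steps, all of which changed the group on the saturated chain carbon. The result for compound 4 is a limit and not a number: the limit of > 10000 nM in this assay, at which 1 of the 4 values shown sits.

On these data alone, it remains open whether an ethyl, a methoxy or a chloro group on this aromatic carbon would keep the value near that of compound 3. As far as these compounds go, it is also open whether removing the methyl from compound 1 or compound 2 would have a similar effect.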